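One Carbon Longer on the Amide-Type Nitrogen Chain

A few compounds are considered here, and "the series" means these few. Any claim that something is new, unique, unknown or untested is made for them only; others in the source may bear on it.

Compound 1 `Cc1nc(N)sc1CCCN/C(N)=N/C(=O)NC1CCCCC1` gives 389 nM in a functional assay on HEK293T cells for agonist activity at histamine H2 receptor (Homo sapiens), read by beta-arrestin recruitment; on this read-out lower numbers stand for an effect already at smaller amounts and higher numbers for an effect only at larger amounts of compound.
Compound 2 `CCCCCNC(=O)/N=C(\N)NCCCc1sc(N)nc1C` gives 178 nM in this assay.
Compound 3 `N/C(=N\C(=O)NCc1ccccc1)NC1CCc2nc(N)sc2C1` gives 4370 nM in this assay.

Among these three numbers compound 2 stands lowest in this assay. Its nearest neighbour is compound 1, whose number is higher by a step that lies beyond the scatter, and its furthest is compound 3, which sits far higher still, so compound 2 is the most potent of the measured set.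

Compound 4 `CCCCCCNC(=O)/N=C(\N)NCCCc1sc(N)nc1C` differs from compound 2 in a single place: methyl in place of hydrogen on a saturated chain carbon, five bonds along the chain from an amide-type nitrogen. Going by the values given here, only one measured step concerns this part of the molecule, a 2.2-fold lower number from compound 1 to compound 2 (0.34 log units; beyond the scatter), in which a cyclohexyl on the amide-type nitrogen was exchanged for a pentyl; that step was modest. Among the compounds with values here, no measured pair shows a methyl added to the end of such a chain, so the present change has no direct precedent here. Since swapping a whole ring for a chain moved the number only modestly, extending that chain by one carbon is expected to move it little, if at all. The expected step of a 1.1-fold lower number from compound 2 to compound 4 (0.05 log units; within the scatter) therefore lies within the scatter. Compound 4 is estimated at 160 nM, with a range from 70 nM to 400 nM.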

Compound 4, half-maximal effective concentration: 85.1 nM
The estimate for compound 4 lay 1.9-fold (0.27 log units) above the measured number, and the stated range covers the measured number.
By their numbers in this assay, from the lowest: compound 4; then compound 2; then compound 1; then compound 3.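

In this assay the position five bonds along the chain from an amide-type nitrogen proves responsive: methyl in place of hydrogen there gives a 2.1-fold lower number from compound 2 to compound 4 (0.32 log units; beyond the scatter) and so is not a silent extension of the chain. This single added methyl moves the number by about as much as the earlier exchange of cyclohexyl for pentyl, which gave a 2.2-fold lower number from compound 1 to compound 2 (0.34 log units; beyond the scatter), so a change far smaller than swapping a ring for a chain carries a comparable step. Hexyl in place of cyclohexyl gives a 4.6-fold lower number from compound 1 to compound 4 (0.66 log units; beyond the scatter) and thus separates the chain from the ring more clearly than pentyl did, though nothing here explains why the number falls.

With only pentyl and hexyl to compare, two chain lengths cannot show whether the number keeps falling with a longer chain such as heptyl or octyl, or whether it levels off or turns back up. Also open, as far as these compounds go, is how this position would respond to a branched chain such as isohexyl, or to a hydroxyl or an amine at the end of the hexyl chain.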